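Ethyl for methyl on the amine of a piperidinone core

This account rests on a few compounds, and the source may have more. Where it says the series, first, only, none or still open, it means among the compounds named here.

The three measured compounds share one core and differ in what hangs from it. Compound 1 `CN1C/C(=C\c2ccccc2F)C(=O)/C(=C/c2ccccc2F)C1` carries two fluorinated rings and a methyl on the ring amine nitrogen. Compound 3 `CCN1C/C(=C\c2ccccc2F)C(=O)/C(=C/c2ccccc2F)C1` is the same except for (methyl in place of hydrogen on a saturated chain carbon bound to an amine nitrogen in a ring). Compound 2 `CN1C/C(=C\c2cc(F)c(F)cc2F)C(=O)/C(=C/c2cc(F)c(F)cc2F)C1` carries more heavily fluorinated rings; how the core of compound 2 differs from the core of compound 1 is not broken down here.

In a functional assay on HCT-116 cells (Homo sapiens) for cytotoxicity, read by MTT assay, with a stated time of 72 h (on this read-out higher numbers stand for weaker inhibition and lower numbers for stronger inhibition), compound 1 gives 1300 nM. Compound 3 gives 1800 nM in this assay, so the change made a 1.4-fold higher number from compound 1 to compound 3 (0.14 log units; within the scatter). Compound 2 gives 1500 nM, which sits within the scatter of both other values, so none of the three can be called stronger or weaker than another.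

The unmeasured compound 4 `CCN1C/C(=C\c2cc(F)c(F)cc2F)C(=O)/C(=C/c2cc(F)c(F)cc2F)C1` stands to compound 2 as compound 3 stands to compound 1: it carries methyl in place of hydrogen on a saturated chain carbon bound to an amine nitrogen in a ring. The two changes sit at the same place and are the same change. Because the earlier step was a 1.4-fold higher number from compound 1 to compound 3 (0.14 log units; within the scatter), a step of similar size is expected here, and the expected step is a 1.4-fold higher number from compound 2 to compound 4 (0.15 log units; within the scatter). This expectation rests only on one earlier pair, so it is held loosely. In this assay compound 4 is expected to give 2100 nM, with a likely range from 1100 nM to 4000 nM.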

Compound 4, half-maximal inhibitory concentration: 510 nM
For compound 4 the middle estimate is 4.1-fold (0.61 log units) above the measured one; the measured number lies below the stated range.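

In this assay, replacing methyl with ethyl on the ring amine nitrogen of the more heavily fluorinated core gives a 2.9-fold lower number from compound 2 to compound 4 (0.47 log units; beyond the scatter), a real gain in cytotoxic strength by the usual standard of repeat measurements. The same change therefore does not carry over at a fixed size from one core to the other, since it makes no readable difference on the core of compound 1 but a clear one on the core of compound 2: the same change on two cores in this assay, a 1.4-fold higher number (0.14 log units; within the scatter) from compound 1 to compound 3 and a 2.9-fold lower number (0.47 log units; beyond the scatter) from compound 2 to compound 4, 4.1-fold (0.61 log units) apart, beyond the scatter of two such steps. This shows that the result of the change depends on the core it is made on, at least for these two pairs, but it does not show why, and two single pairs are too few to support a general rule about cores with more fluorine on their rings.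

The compounds shown leave open whether a longer chain on the nitrogen, such as propyl or butyl, would lower the number further on the core of compound 2 or would reverse the gain. They also leave open which of the added fluorines matter for the difference between the two cores, as a core carrying only one added fluorine on each ring could begin to separate them.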